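Dropping the trifluoromethyl group from compound 2

The source may hold more compounds than are shown below. What is called first, only, known or untested is meant among the compounds shown, and "the series" means these compounds.

Compound 1 `O=C(CCCCC(S)CCS)Nc1ccc(OC(F)(F)F)cc1`: 14.2%
Compound 2 `O=C(CCCCC(S)CCS)Nc1ccc([N+](=O)[O-])c(C(F)(F)F)c1`: "not active" (no number reported)

Both compounds were tested in a functional assay on Bel-7402 cells (Homo sapiens) for inhibition, read by MTT assay, with a stated time of 24 h, tested at 10 ug/mL; on this read-out higher numbers stand for more inhibition of growth at the one concentration tested and lower numbers for less inhibition of growth. There, compound 1 gives 14.2%, a low figure. Compound 2 has no single number and is recorded only as "not active" (no number reported). For the measured compounds named here, the two differ in more than one place, and no single-change step connects them.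

Compound 3 `O=C(CCCCC(S)CCS)Nc1ccc([N+](=O)[O-])cc1` has not yet been measured. It differs from compound 2 in one place: hydrogen in place of trifluoromethyl on an aromatic carbon. The rest of the structure stays the same, including the nitro group.

With no number for compound 2, the size of this step cannot be worked out from the data. A small upward step in this assay is expected, and it may well stay within the usual scatter. Going by the values given here, the only number available for this series is the low one for compound 1, at 14.2%, so a weak result is expected for compound 3 too. The estimate for compound 3 is 12%, with an expected range of 0% to 30%.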

Compound 3, percent growth inhibition at one concentration: 14.4%
For compound 3 the middle estimate is 2.4 percentage points below the measured one, and the stated range covers the measured number.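

In this assay compound 3, which has hydrogen in place of the trifluoromethyl group, gives a number (14.4%), whereas compound 2 is recorded only as ("not active" (no number reported)), so the size of that step cannot be read. For the compounds shown here, what the new result does allow is a first clean comparison at the other place on the aromatic ring: nitro in place of trifluoromethoxy gives a number 0.2 percentage points higher from compound 1 to compound 3 (within the scatter), which means that these two groups cannot be told apart in this assay, and both compounds give only a modest figure at the single concentration tested. No other measurement is at hand that could explain these figures.

Going by these compounds, it remains open whether an amine or a carboxylic acid in place of the nitro group would move the figure beyond the usual scatter of this read-out. Going by these compounds alone, also unresolved is whether a longer chain in place of the one shared by these compounds would change the result, and a single concentration cannot show how the compounds would behave at other doses.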